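Trimming an Isopropyl Group to Ethyl

The source may report more compounds than this note shows. Statements on the series, on what has been measured and on what is new or still open speak of the compounds shown alone.

In a functional assay on HeLa cells (Homo sapiens) for inhibition (a higher number here means a weaker inhibitor, a lower number a stronger inhibitor), compound 1 `O=C1C=CC(OCC(F)(F)F)N1c1cc(Cl)cc(Cl)c1` gives 5920 nM and compound 2 `CC(C)c1ccc(N2C(=O)C=CC2OCC(F)(F)F)cc1` gives 5800 nM so these two values lie within the scatter of each other. Compound 3 `CCc1ccc(N2C(=O)C=CC2OCC(F)(F)F)cc1` has not yet been measured. It changes the isopropyl of compound 2 to ethyl, with hydrogen in place of methyl on a saturated chain carbon bound to an aromatic carbon and a saturated chain carbon. Within the data shown here, no measured pair shows this change, so the expected step of a 1.0-fold higher number from compound 2 to compound 3 (0.01 log units; within the scatter) is none beyond the scatter. For compound 3 the estimated value is 6000 nM (expected range 2500 nM to 14000 nM).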

Compound 3, half-maximal inhibitory concentration: 6510 nM
The estimate for compound 3 lay 1.1-fold (0.04 log units) below the measured number, within the range that was stated.
By their numbers in this assay, from the lowest: compounds 2, 1 and 3 (each within the scatter of the next).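

Replacing isopropyl with ethyl, with hydrogen in place of methyl on a saturated chain carbon bound to an aromatic carbon and a saturated chain carbon, gives a 1.1-fold higher number from compound 2 to compound 3 (0.05 log units; within the scatter) in this assay. Among these compounds, this is the first direct reading of this change, and it shows that at this place one methyl can be removed without a difference that this assay can resolve. Nothing shown here gives a reason for this result.

Still open, going by these compounds, is whether a longer chain, a tert-butyl group or an amine in place of the ethyl would move the number beyond the scatter. A single step also cannot show whether the same change would behave alike on a different core.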